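Urea aryl swap from compound 1 to compound 4

This account rests on a few compounds, and the source may have more. Where it says the series, first, only, none or still open, it means among the compounds named here.

Measured in a functional assay on A549 cells (Homo sapiens) for inhibition, read by MTT assay, with a stated time of 48 h; on this read-out lower numbers stand for stronger inhibition and higher numbers for weaker inhibition:
- Compound 1 `Cc1ccc(NC(=O)Nc2cccc(-c3cccc4[nH]nc(N)c34)c2)cc1Cl`: 1750 nM
- Compound 2 `Nc1n[nH]c2cccc(-c3cccc(NC(=O)Nc4ccc(F)c(F)c4)c3)c12`: 3040 nM
- Compound 3 `Nc1n[nH]c2cccc(-c3cccc(NC(=O)Nc4nccs4)c3)c12`: > 500000 nM

Compound 1, at 1750 nM, stands with compound 2 among the two numerical values in this assay, and the gap is a 1.7-fold higher number from compound 1 to compound 2 (0.24 log units; within the scatter). The value of compound 3 is a limit of the assay, not a number.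

Compound 4 `Nc1n[nH]c2cccc(-c3cccc(NC(=O)Nc4ccccc4F)c3)c12` has not yet been measured. Its difference from compound 1 is 2-fluorophenyl in place of 3-chloro-4-methylphenyl on an amide-type nitrogen.

Among the measured compounds shown here, three measured steps bear on this change. The closest guide is the change to 3,4-difluorophenyl, which gave a 1.7-fold higher number from compound 1 to compound 2 (0.24 log units; within the scatter). The changes to 1,3-thiazol-2-yl gave an at least 280-fold higher number from compound 1 to compound 3 (2.45 log units; beyond the scatter) and an at least 160-fold higher number from compound 2 to compound 3 (2.21 log units; beyond the scatter), but 2-fluorophenyl remains a six-membered aromatic ring of carbon only. A small move to a higher number is therefore expected, not clearly beyond the scatter. The expected step is a 1.8-fold higher number from compound 1 to compound 4 (0.26 log units; within the scatter). The estimate for compound 4 is 3200 nM, with an expected range of 1000 nM to 12000 nM.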

Compound 4, half-maximal inhibitory concentration: 1170 nM
For compound 4 the middle estimate is 2.7-fold (0.44 log units) above the measured one; low and high end bracket the measured number.
By their numbers in this assay, from the lowest: compounds 4, 1 and 2 (each within the scatter of the next, the first and the last beyond it). At a limit, above all of these: compound 3.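

In this assay, among the compounds shown here, 2-fluorophenyl on the amide-type nitrogen serves as well as 3-chloro-4-methylphenyl, with a 1.5-fold lower number from compound 1 to compound 4 (0.17 log units; within the scatter), yet it gives the only step among the three phenyl groups that passes the scatter, a 2.6-fold lower number from compound 2 to compound 4 (0.41 log units; beyond the scatter), so the substituents on the phenyl ring do register here, if only modestly. The 2-fluorophenyl group also stands far from the 1,3-thiazol-2-yl group, with an at least 420-fold lower number from compound 3 to compound 4 (2.63 log units; beyond the scatter). The value of compound 3 is a limit and not a number: the limit of > 500000 nM in this assay, at which 1 of the 4 values shown sits.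

As far as these compounds go, what an unsubstituted phenyl, a pyridine ring or a 2-methoxyphenyl group would give on this nitrogen remains open. So does whether the loss seen with 1,3-thiazol-2-yl extends to other five-membered rings or belongs to that ring alone.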